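The source may report more compounds than this note shows. Statements on the series, on what has been measured and on what is new or still open speak of the compounds shown alone.

Compound 3 (`COC(=O)CC/C=C\CC[C@H]1C(=O)C[C@@H](O)[C@@H]1/C=C/C[C@@](C)(O)/C=C/C(C)=C(C)C`) gives only a limit in a functional assay on the whole organism with Rattus norvegicus as the target (a lower number here means that less compound is needed, a higher number that more compound is needed for the effect), > 3.16 mg/kg. Compound 2 (`COC(=O)CC/C=C\CC[C@H]1C(=O)C[C@@H](O)[C@@H]1/C=C/C[C@@](C)(O)/C=C/C=C(C)C`) also gives only a limit, > 3.16 mg/kg. Compound 1 (`C/C=C\C=C\[C@](C)(O)C/C=C/[C@H]1[C@H](O)CC(=O)[C@@H]1CC/C=C\CCC(=O)OC`) gives a measured number, 0.306 mg/kg. Compound 4 (`C=C/C=C/[C@](C)(O)C/C=C/[C@H]1[C@H](O)CC(=O)[C@@H]1CC/C=C\CCC(=O)OC`) has vinyl in place of 1,2-dimethylprop-1-en-1-yl on a double-bonded chain carbon bound to a double-bonded chain carbon. The closest evidence comes from compound 1, which carries prop-1-en-1-yl at this place. Large steps beyond the scatter were seen an at least 10-fold higher number from compound 1 to compound 2 (1.01 log units; beyond the scatter) and an at least 10-fold higher number from compound 1 to compound 3 (1.01 log units; beyond the scatter), and the limits leave the step that the two limits leave unreadable from compound 2 to compound 3 unreadable. Vinyl is a small group like prop-1-en-1-yl, so a large fall in the dose is expected, back toward the value of compound 1, 0.306 mg/kg. The expected change is an at least 5.2-fold lower number from compound 3 to compound 4 (0.72 log units; beyond the scatter). For compound 4, the estimated dose is 0.6 mg/kg, within an expected range of 0.15 mg/kg to 2.5 mg/kg.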

Compound 4, dose for half-maximal effect: 0.243 mg/kg
The estimate for compound 4 lay 2.5-fold (0.39 log units) above the measured number; measured number inside the range.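

Vinyl at this place on the double-bonded chain carbon brings the dose back down in this assay, with an at least 13-fold lower number from compound 3 to compound 4 (1.11 log units; beyond the scatter) and an at least 13-fold lower number from compound 2 to compound 4 (1.11 log units; beyond the scatter). Vinyl and prop-1-en-1-yl cannot be told apart here, with a 1.3-fold lower number from compound 1 to compound 4 (0.10 log units; within the scatter), so the end methyl of prop-1-en-1-yl is not needed for the effect. Compound 2 and compound 3 both stand at a limit, so the step between them cannot be read: the limit of > 3.16 mg/kg in this assay, at which 2 of the 4 values shown sit.

Still open, on these data alone, is how a saturated ethyl group or an amine at this place would behave. Also open, as far as these compounds go, is whether a longer unbranched chain, such as penta-1-en-1-yl, keeps the low dose.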